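The source may report more compounds than this note shows. Statements on the series, on what has been measured and on what is new or still open speak of the compounds shown alone.

Measured compounds:
compound 1 `COc1ccc(CN(c2cc(OC)c(OC)c(OC)c2)S(=O)(=O)c2ccc(C)cc2)cc1`: 8220 nM
compound 2 `COc1cc(N(Cc2ccc(F)cc2)S(=O)(=O)c2ccc(C)cc2)cc(OC)c1OC`: 20700 nM
compound 3 `COc1cc(N(Cc2nc3ccccc3[nH]2)C(=O)c2ccccc2)cc(OC)c1OC`: > 50000 nM

All three were tested in a functional assay on PC-3 cells (Homo sapiens) for inhibition, read by MTT assay, with a stated time of 48 h; a lower number here means a stronger inhibitor, a higher number a weaker inhibitor. Among the measured compounds shown here, compound 1 gives 8220 nM and compound 2 gives 20700 nM; the single step within the measured set, a 2.5-fold higher number from compound 1 to compound 2 (0.40 log units; beyond the scatter), is the only comparison available. For compound 3 the result is a limit, (the limit of > 50000 nM in this assay, at which 1 of the 3 values shown sits), so compound 3 cannot be placed against the other two beyond that. Compound 4 `COc1ccc(C(=O)N(Cc2nc3ccccc3[nH]2)c2cc(OC)c(OC)c(OC)c2)cc1OC` differs from compound 3 by 3,4-dimethoxyphenyl in place of phenyl on a carbonyl carbon. For the measured compounds named here, no measured step bears directly on this change; the nearest is the exchange of a methoxy on an aromatic carbon for fluoro, a 2.5-fold higher number from compound 1 to compound 2 (0.40 log units; beyond the scatter), which moved the number by a modest amount. Adding two methoxy groups might therefore be expected to lower the number in this assay by a similarly modest amount at most, and from a starting point that is itself a limit this leaves little room. Compound 4 is therefore estimated at 40000 nM, with a range from 15000 nM to 100000 nM, and the expected step of an at least 1.2-fold lower number from compound 3 to compound 4 (0.09 log units; that floor lies within the scatter) is small, with a fair chance that the assay again reports only a limit.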

Compound 4, half-maximal inhibitory concentration: 34900 nM
The estimate for compound 4 lay 1.1-fold (0.06 log units) above the measured number, within the range that was stated.
By their numbers in this assay, from the lowest: compound 1; then compounds 2 and 4 (each within the scatter of the next). At a limit, above all of these: compound 3.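

With 3,4-dimethoxyphenyl in place of phenyl on the carbonyl carbon, this amide-type pair gains a number that can be read in this assay: compound 4 gives 34900 nM. The change amounts to an at least 1.4-fold lower number from compound 3 to compound 4 (0.15 log units; that floor lies within the scatter), so only a floor is known, and that floor does not establish a real gain. The true size of the step cannot be read, because the value for compound 3 is only a limit: the limit of > 50000 nM in this assay, at which 1 of the 4 values shown sits.

The compounds shown leave open whether a single methoxy on the phenyl would give the same reading, and what an amine or a carboxylic acid on that ring would do. They also leave open how this amide-type pair relates to compound 1 and compound 2, since these differ from it in more than one place.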